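A few compounds are considered here, and "the series" means these few. Any claim that something is new, unique, unknown or untested is made for them only; others in the source may bear on it.

Measured compounds:
compound 1 `Cc1cccc(NC(=O)CN2CCN(c3ccc(Cl)cn3)CC2)c1`: "not active" (no number reported)
compound 2 `Cc1cccc(NC(=O)CN2CCN(c3ncccn3)CC2)c1`: 278 nM
compound 3 `Cc1cccc(NC(=O)CN2CCN(c3ccccn3)CC2)c1`: 394 nM

In an assay on cells for agonist activity at D(4) dopamine receptor (Homo sapiens), read by luminescence and beta-arrestin recruitment, with a stated time of 90 min (on this read-out higher numbers stand for an effect only at larger amounts of compound and lower numbers for an effect already at smaller amounts), compound 1 is recorded as "not active" (no number reported), with no number attached, so it cannot be placed against the other two on a scale. Compound 2 and compound 3 differ from compound 1 only in the aryl group on the amine nitrogen of the ring; in this assay compound 2 gives 278 nM and compound 3 gives 394 nM, and the step of a 1.4-fold higher number from compound 2 to compound 3 (0.15 log units; within the scatter) lies within the scatter. Nothing further can be said about how compound 1 relates to them, since no number exists for it.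

Compound 4 `O=C(CN1CCN(c2ccc(Cl)cn2)CC1)Nc1cncnc1` keeps the chloropyridinyl part of compound 1 and changes the other end of the molecule: pyrimidin-5-yl in place of 3-methylphenyl on an amide-type nitrogen. For the measured compounds named here, none of the measured steps touches the amide-type nitrogen or the group on it, so no measured step bears on this change, and its direction or size in this assay cannot be read from the data. Because compound 1 stands at "not active" (no number reported), the expectation for compound 4 is that it too may be recorded without a number. If a number is obtained, compound 4 is estimated at 3000 nM, with a range from 400 nM to 20000 nM.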

Compound 4, half-maximal effective concentration: "not active" (no number reported)
Compound 4: no number reported, so the estimate cannot be set against anything.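

In this assay compound 1 gives "not active" (no number reported) and compound 4 gives "not active" (no number reported) so no step can be read between compound 1 and compound 4. No supporting evidence bears on this result. The compounds shown leave open whether pyrimidin-5-yl in place of 3-methylphenyl on an amide-type nitrogen changes this read-out at all.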